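Swapping a Fluoromethoxyphenyl Ring for a Fluoropyridyl Ring

The source may hold more compounds than are shown below. What is called first, only, known or untested is meant among the compounds shown, and "the series" means these compounds.

Three relatives of one shared core have been tested in an ADME assay on Vero cells (Chlorocebus sabaeus) for cytotoxicity, with a stated time of 72 h; a lower number here means a stronger inhibitor, a higher number a weaker inhibitor. Compound 1 `O=[N+]([O-])c1cn2c(n1)OC[C@@H](OCc1ccc(-c3ccc(F)cc3)s1)C2` gives > 128000 nM, which is a limit of the assay, not a number. Compound 2 `COc1ccc(-c2ccc(CO[C@@H]3COc4nc([N+](=O)[O-])cn4C3)s2)cc1F` gives > 128000 nM, again only a limit. Compound 3 `O=[N+]([O-])c1cn2c(n1)OC[C@@H](OCc1ccc(-c3ccc(OC(F)F)cc3)s1)C2` gives > 128000 nM, also a limit. Compound 2 thus stands where every measured compound stands, as summed up by the limit of > 128000 nM in this assay, at which 3 of the 3 values shown sit, and the steps a step that the two limits leave unreadable from compound 1 to compound 2 and a step that the two limits leave unreadable from compound 1 to compound 3 carry no readable size. Compound 4 `O=[N+]([O-])c1cn2c(n1)OC[C@@H](OCc1ccc(-c3cncc(F)c3)s1)C2` differs from compound 2 by 5-fluoropyridin-3-yl in place of 3-fluoro-4-methoxyphenyl on an aromatic carbon. With both measured steps unreadable, compound 4 is expected to sit at the limit as well, so the expected step that the limit leaves unreadable from compound 2 to compound 4 is nil. The estimate for compound 4 is 150000 nM, between 60000 nM and 400000 nM.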

Compound 4, half-maximal inhibitory concentration: > 128000 nM
Compound 4 gave a limit, no number; the forecaster's own chance of this, stated with the estimate: 85%; the middle value is on the limit's open side.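

The steps from compound 1 and compound 2 to compound 4 cannot be read, because all these compounds sit at one limit: the limit of > 128000 nM in this assay, at which 4 of the 4 values shown sit.

The compounds shown leave open whether any of these ring swaps changes the read-out in this assay at all.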